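Benzyloxy to hexyloxy on the shared core

A few compounds are considered here, and "the series" means these few. Any claim that something is new, unique, unknown or untested is made for them only; others in the source may bear on it.

Compound 1 `CN(C)CCNc1ccnc2cc(OCc3ccccc3)ccc12` gives 2350 nM in a functional assay on RKO cells (Homo sapiens) for cytotoxicity, read by MTT assay, with a stated time of 48 h (a lower number here means a stronger inhibitor, a higher number a weaker inhibitor), and stands lowest of the two numbers in hand, though compound 2 `Clc1ccnc2cc(OCc3ccccc3)ccc12` gives 2410 nM and the step of a 1.0-fold higher number from compound 1 to compound 2 (0.01 log units; within the scatter) sits within the scatter. Compound 3 `CCCCCCOc1ccc2c(NCCN(C)C)ccnc2c1` differs from compound 1 by pentyl in place of phenyl on a saturated chain carbon bound to an oxygen on an aromatic ring. Among the compounds with values here, the one measured step alters another part of the core and does not bear on this change, and no other comparison exists for it. The expected step is therefore a 1.0-fold higher number from compound 1 to compound 3 (0.01 log units; within the scatter), with no direction beyond the scatter. Compound 3 is estimated at 2400 nM, ranging from 1000 nM to 6000 nM.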

Compound 3, half-maximal inhibitory concentration in the RKO assay: 1120 nM
Estimate against measurement, compound 3: 2.1-fold (0.33 log units) above; the measured number falls inside the stated range.
By their numbers in the RKO assay, from the lowest: compound 3; then compounds 1 and 2 (each within the scatter of the next).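

In the RKO assay this place on the saturated chain carbon bound to an oxygen on an aromatic ring moves the number, with a 2.1-fold lower number from compound 1 to compound 3 (0.32 log units; beyond the scatter) and a chain without a ring in place of the benzyl group. In a physicochemical assay for solubility (on this read-out lower numbers stand for lower solubility and higher numbers for higher solubility), compound 1 gives > 10000 ug/mL as a limit of the assay. In the physicochemical assay compound 3 also gives > 10000 ug/mL as a limit, and the step between them cannot be read: the limit of > 10000 ug/mL in the physicochemical assay, at which 2 of the 2 values shown sit.

Still open, going by these compounds, is whether the step follows the hexyl chain itself or the loss of the phenyl ring. A longer chain or a cyclohexylmethyl group at this place would separate the two.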